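The source may hold more compounds than are shown below. What is called first, only, known or untested is meant among the compounds shown, and "the series" means these compounds.

In a functional assay on LNCaP cells (Homo sapiens) for antiproliferative activity (on this read-out lower numbers stand for stronger inhibition and higher numbers for weaker inhibition), compound 3 (`CN(C)CC[C@@H]1C[C@@H](c2ccc(Cl)c(Cl)c2)[C@H](NC(=O)c2cc(-c3c(Cl)cnn3C)c(Cl)o2)CN1`) gives 1930 nM, within the scatter of compound 1 (`Cn1ncc(Cl)c1-c1cc(C(=O)N[C@@H]2CN[C@H](CCN3CCC(O)CC3)C[C@H]2c2ccc(Cl)c(Cl)c2)oc1Cl`) at 1140 nM and of compound 2 (`Cn1ncc(Cl)c1-c1cc(C(=O)N[C@@H]2CN[C@H](CCN3CCCCC3)C[C@H]2c2ccc(Cl)c(Cl)c2)oc1Cl`) at 1780 nM. Compound 4 (`Cn1ncc(Cl)c1-c1cc(C(=O)N[C@@H]2CN[C@H](CC(=O)NCCO)C[C@H]2c2ccc(Cl)c(Cl)c2)oc1Cl`) differs from compound 3 by (2-hydroxyethyl)carbamoyl in place of (dimethylamino)methyl on a saturated chain carbon bound to a saturated ring carbon, with (2-hydroxyethyl)carbamoyl in place of (dimethylamino)methyl on a saturated chain carbon bound to a saturated ring carbon. Among the measured compounds shown here, three measured steps bear on this chain end: a 1.6-fold higher number from compound 1 to compound 2 (0.19 log units; within the scatter), a 1.7-fold higher number from compound 1 to compound 3 (0.23 log units; within the scatter) and a 1.1-fold higher number from compound 2 to compound 3 (0.04 log units; within the scatter). All three lie within the scatter. For the measured compounds named here, none of the measured compounds carries the carbamoyl group, so they guide the estimate only loosely. The expected change in this assay is a 1.3-fold higher number from compound 3 to compound 4 (0.11 log units; within the scatter), with no clear step beyond the scatter anticipated. Compound 4 is estimated at 2500 nM, within an expected range of 900 nM to 7000 nM.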

Compound 4, half-maximal inhibitory concentration: 40 nM
The estimate for compound 4 lay 63-fold (1.80 log units) above the measured number; the whole stated range lies above it.
By their numbers in this assay, from the lowest: compound 4; then compounds 1, 2 and 3 (each within the scatter of the next).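

Among the compounds shown here, the chain end matters far more in this assay than the earlier compounds suggested: their three amine-ended chains lay within the scatter of one another, yet (2-hydroxyethyl)carbamoyl gives a 48-fold lower number from compound 3 to compound 4 (1.68 log units; beyond the scatter), a 45-fold lower number from compound 2 to compound 4 (1.65 log units; beyond the scatter) and a 29-fold lower number from compound 1 to compound 4 (1.45 log units; beyond the scatter). A hydroxy group alone does not match this, as compound 1 also carries one and stays within the scatter of compound 2. Nothing available accounts for the size of this step. The compounds shown do not separate the amide from its terminal hydroxy. A plain carboxamide or a carboxylic acid at this chain end would address that.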